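The source may hold more compounds than are shown below. What is called first, only, known or untested is meant among the compounds shown, and "the series" means these compounds.

The measured compounds and their readings in a functional assay on KYSE-510 cells (Homo sapiens) for antiproliferative activity, read by crystal violet staining, with a stated time of 96 h; a higher number here means a weaker inhibitor of growth, a lower number a stronger inhibitor of growth:

Compound 1 `O=S(=O)(NC1=NCCN1C(=S)SN1CCn2c1nsc2=S)c1ccccc1` gives >= 20000 nM, a limit of the assay rather than a number.
Compound 2 `Cc1cc(C)c(S(=O)(=O)NC2=NCCN2C(=S)SN2CCn3c2nsc3=S)c(C)c1` gives >= 20000 nM, likewise a limit.
Compound 3 `COc1cccc(S(=O)(=O)NC2=NCCN2C(=S)SN2CCn3c2nsc3=S)c1` gives >= 20000 nM, again a limit.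

Compound 3 thus stands at the same limit as the other two; none of the three readings is a number, and the limit of >= 20000 nM in this assay, at which 3 of the 3 values shown sit, shows that all three values sit at that limit. The steps a step that the two limits leave unreadable from compound 1 to compound 2, a step that the two limits leave unreadable from compound 1 to compound 3 and a step that the two limits leave unreadable from compound 2 to compound 3 are therefore of unreadable size. Compound 4 `CC(=O)Nc1ccc(S(=O)(=O)NC2=NCCN2C(=S)SN2CCn3c2nsc3=S)cc1` differs from compound 3 in one place: 4-acetamidophenyl in place of 3-methoxyphenyl on a sulfonyl sulfur. Each measured step bears on this change only in that it, too, alters the group on the sulfonyl sulfur, and none of them has a readable size. No step beyond the scatter can be expected in either direction in this assay, and a reading at the same limit looks the most likely outcome. Compound 4 is therefore estimated at 20000 nM, within 5000 nM to 60000 nM. The resulting step is expected to be a number no higher from compound 3 to compound 4 (the limit leaves the size open).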

Compound 4, concentration for 50% growth inhibition: >= 20000 nM
Compound 4 gave a limit, no number; the forecaster's own chance of this, stated with the estimate: 85%; the middle value sits exactly at the limit.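

No step can be read between compound 4 and compound 1, compound 2 or compound 3 in this assay, as all four readings are limits, not numbers: the limit of >= 20000 nM in this assay, at which 4 of the 4 values shown sit.

The compounds shown leave open whether changing the group on the sulfonyl sulfur alters growth inhibition at all.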